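A few compounds are considered here, and "the series" means these few. Any claim that something is new, unique, unknown or untested is made for them only; others in the source may bear on it.

Of the compounds shown here, three have been measured in a functional assay on T-24 cells (Homo sapiens) for antiproliferative activity, read by MTT assay, with a stated time of 72 h (a lower number here means a stronger inhibitor, a higher number a weaker inhibitor), all sharing a core in which a chain of two guanidine-like units links an aryl ring to an alkylated nitrogen. Compound 1 `CCN(C)C(=N)NC(=N)Nc1ccc(C(F)(F)F)cc1` gives 5700 nM, compound 3 `CC(C)CNC(=N)NC(=N)Nc1ccc(C(F)(F)F)cc1` gives 3100 nM, and compound 2 `CCCCCCCNC(=N)NC(=N)Nc1ccc(F)c(F)c1` gives 4300 nM, which places compound 2 second highest of the three, with every gap between it and the others inside the usual scatter. Among the measured compounds shown here, the only single change measured so far is a 1.8-fold lower number from compound 1 to compound 3 (0.26 log units; within the scatter), and it stayed within the scatter.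

Compound 4 `CC(C)NC(=N)NC(=N)Nc1ccc(F)c(F)c1` differs from compound 2 at the same kind of position: isopropyl in place of heptyl on an amine nitrogen. For the measured compounds named here, the step from compound 1 to compound 3 is the one comparison that bears on swapping one alkyl group for another at this nitrogen, and it showed little movement, so a step in this assay of only modest size, in no clear direction, is expected: a 1.2-fold higher number from compound 2 to compound 4 (0.07 log units; within the scatter). Compound 4 is therefore estimated at 5000 nM, within a range from 2000 nM to 12000 nM.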

Compound 4, half-maximal inhibitory concentration: 45000 nM
Compound 4: middle estimate off by 9.0-fold (0.95 log units), on the low side; the measured number lies above the stated range.
By their numbers in this assay, from the lowest: compounds 3, 2 and 1 (each within the scatter of the next); then compound 4.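

In this assay the alkyl group on this amine nitrogen can matter a great deal, since replacing heptyl with isopropyl gives a 10-fold higher number from compound 2 to compound 4 (1.02 log units; beyond the scatter) and moves the number well past the scatter. The earlier alkyl swap at this kind of nitrogen gave only a 1.8-fold lower number from compound 1 to compound 3 (0.26 log units; within the scatter) and stayed within the scatter, so a small step cannot be taken as the rule here. Nothing available explains this large step.

A pentyl chain on the core of compound 2 would help show whether the number climbs gradually as the chain is cut back or whether isopropyl is a special case. From the compounds shown here alone, it also remains open whether swapping heptyl for isopropyl would have a similar effect on the trifluoromethyl-bearing core of compound 1.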